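Aryl swap on the ring nitrogen of compound 3

The compounds below may be only part of what the source reports. "The series", "measured", "known", "first", "only" and "open" are said of these compounds alone.

Measured so far:
compound 1 `CCCc1nc(-c2ccccc2)c(CNCCN2CCN(C(c3ccccc3)c3ccccc3)CC2)o1`: 71.9%
compound 2 `CCCc1nc(-c2ccccc2)c(CNCCCN2CCN(c3ccc(C(F)(F)F)cc3)CC2)o1`: 51.6%
compound 3 `CCCc1nc(-c2ccccc2)c(CNCCN2CCN(c3ccccn3)CC2)o1`: 48.1%

In an assay on HEK293 cells for inhibition of Voltage-dependent T-type calcium channel subunit alpha-1G (Homo sapiens), read by fluorescence, tested at 10 uM (on this read-out lower numbers stand for less inhibition and higher numbers for more inhibition at the one concentration tested (going by the name of the read-out)), compound 3 gives the lowest of the three numbers. Compound 2 sits close to it, and the two lie within the scatter of each other. Compound 1 stands beyond the scatter above compound 3. Compound 4 `CCCc1nc(-c2ccccc2)c(CNCCN2CCN(c3ccc(OC)cc3)CC2)o1` has not been measured. It differs from compound 3 in one place: 4-methoxyphenyl in place of pyridin-2-yl on an amine nitrogen in a ring, on an amine nitrogen in a ring. For the measured compounds named here, no measured pair shows this kind of change, so the step is estimated from compound 2 and compound 3 alone, and the expected step is a number 3.9 percentage points higher from compound 3 to compound 4 (within the scatter), no larger than the scatter. Compound 4 is therefore expected to give 52%, between 35% and 70%.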

Compound 4, a percentage reported as inhibition, at one concentration (the size of the read-out at that concentration, not a potency): 51.5%
Beside the measured number, compound 4's estimate is 0.5 percentage points above it; the measured number falls inside the stated range.
By their numbers in this assay, from the lowest: compounds 3, 4 and 2 (each within the scatter of the next); then compound 1.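

In this assay, putting 4-methoxyphenyl in place of pyridin-2-yl on the amine nitrogen in the ring gives a number 3.4 percentage points higher from compound 3 to compound 4 (within the scatter). This first single-place comparison at this position shows that, for this pair, an aromatic ring of carbon only carrying methoxy and a pyridine ring cannot be told apart. Nothing measured here speaks to a cause for this result.

The compounds shown leave open whether a non-aromatic group on this nitrogen, such as cyclohexyl or acetyl, would give a similar number. They also leave open how a carboxylic acid or an amine on the phenyl ring would read.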